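The source may hold more compounds than are shown below. What is called first, only, known or untested is meant among the compounds shown, and "the series" means these compounds.

Measured so far in a physicochemical assay for solubility, in phosphate buffer, with a stated time of 18 h, at pH 7; on this read-out higher numbers stand for higher solubility and lower numbers for lower solubility:
- compound 1, `CC(=O)N1CCCC([C@@H]2[C@@H](C(=O)Nc3ccc(F)c(C#N)c3)c3ccccc3C(=O)N2CC(C)C)C1`: 69000 nM
- compound 2, `CC(C)CN1C(=O)c2ccccc2[C@H](C(=O)Nc2ccc(F)c(C#N)c2)[C@H]1c1ccc(C#N)s1`: 4900 nM
- compound 3, `CC(C)CN1C(=O)c2ccccc2[C@H](C(=O)Nc2ccc(F)c(C#N)c2)[C@H]1c1ccc(C(N)=O)s1`: 19000 nM

Compound 3 stands second highest of the three numbers; compound 1 sits above it, a 3.6-fold lower number from compound 1 to compound 3 (0.56 log units; beyond the scatter), and compound 2 sits below it, a 3.9-fold higher number from compound 2 to compound 3 (0.59 log units; beyond the scatter) read in reverse.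

The step now considered goes from compound 3 to compound 4, `CC(C)CN1C(=O)c2ccccc2[C@H](C(=O)Nc2ccc(F)c(C#N)c2)[C@H]1c1cnsc1`. The change is 1,2-thiazol-4-yl in place of 5-carbamoylthiophen-2-yl on a saturated ring carbon. The group leaving carries the carbamoyl that distinguishes compound 3 from compound 2; the group entering has no hydrogen-bond donor, as in compound 2.

For the measured compounds named here, two measured steps bear on this. The step of a 3.9-fold higher number from compound 2 to compound 3 (0.59 log units; beyond the scatter) shows that putting carbamoyl in place of cyano on the thiophene raised the number by a modest amount; removing the carbamoyl and going to a small azole with no donor is expected to run the other way. The step of a 3.6-fold lower number from compound 1 to compound 3 (0.56 log units; beyond the scatter) shows that this aryl position can move this assay by a modest amount on its own. A modest decrease is therefore expected, a 2.7-fold lower number from compound 3 to compound 4 (0.43 log units; beyond the scatter), landing compound 4 near compound 2 rather than compound 1.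

For compound 4 the expected value in this assay is 7000 nM, with a range from 2500 nM to 20000 nM.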

Compound 4, solubility: 20000 nM
For compound 4 the middle estimate is 2.9-fold (0.46 log units) below the measured one; the measured number falls inside the stated range.
By their numbers in this assay, from the lowest: compound 2; then compounds 3 and 4 (each within the scatter of the next); then compound 1.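

At this saturated ring carbon in this assay, the exchange of 5-carbamoylthiophen-2-yl for 1,2-thiazol-4-yl gives a 1.1-fold higher number from compound 3 to compound 4 (0.02 log units; within the scatter) and so leaves the two groups indistinguishable, showing that this read-out can hold its level here with 0 hydrogen-bond donors on the group and with 8 heavy atoms cut to 5. Compound 2 now stands apart at the low end, with a 4.1-fold higher number from compound 2 to compound 4 (0.61 log units; beyond the scatter) matching in size the gap already seen on going to the carbamoyl, so among the aromatic groups shown the low number belongs to 5-cyanothiophen-2-yl alone and not to the absence of a donor. The saturated group keeps its lead, with a 3.5-fold lower number from compound 1 to compound 4 (0.54 log units; beyond the scatter) placing 1-acetylpiperidin-3-yl beyond the scatter of 1,2-thiazol-4-yl, as it is of the other two aromatic groups.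

On these data alone, how the number responds to a carboxylic acid or an aminomethyl group on a five-membered aromatic ring at this carbon remains open, as does the effect of a carbamoyl on the 1,2-thiazol-4-yl ring itself. No measurement at hand accounts for any of these gaps.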